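The source may report more compounds than this note shows. Statements on the series, on what has been measured and on what is new or still open speak of the compounds shown alone.

Working notes on the sulfonyl series.

Compound 1 `CC(C)n1cc(S(=O)(=O)c2ccc(CNC(=O)N3Cc4ccncc4C3)cc2)cn1` sits lowest of the three numbers in an ADME assay on microsomes from liver (Homo sapiens) for pharmacokinetics, read by LC-MS, with a stated time of 60 min, tested at 1 uM (a higher number here means faster removal of the compound, a lower number slower removal), where compound 1 gives 4 mL/min/kg. Its nearest neighbour is compound 2 `CC(=O)N1CCC(S(=O)(=O)c2ccc(CNC(=O)N3Cc4ccncc4C3)cc2)CC1`, which in this assay gives 6 mL/min/kg; the furthest is compound 3 `CCC(=O)N1CCC(S(=O)(=O)c2ccc(CNC(=O)N3Cc4ccncc4C3)cc2)CC1`, which in this assay gives 11 mL/min/kg. The steps are a 1.5-fold higher number from compound 1 to compound 2 (0.18 log units; within the scatter), a 2.8-fold higher number from compound 1 to compound 3 (0.44 log units; beyond the scatter) and a 1.8-fold higher number from compound 2 to compound 3 (0.26 log units; within the scatter).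

Compound 4 `CN1CCN(S(=O)(=O)c2ccc(CNC(=O)N3Cc4ccncc4C3)cc2)CC1` is the next variation on the same sulfonyl sulfur: 4-methylpiperazin-1-yl in place of 1-isopropyl-1H-pyrazol-4-yl on a sulfonyl sulfur. The two steps that bear on it are those from compound 1 to compound 2 and from compound 1 to compound 3, since each also swaps 1-isopropyl-1H-pyrazol-4-yl for a six-membered non-aromatic ring with 2 hetero atoms on that sulfur; one stayed within the scatter and one was modest, both toward a higher number. The expectation for compound 4 is therefore a small move upward in this assay, plausibly within the scatter, as a 1.5-fold higher number from compound 1 to compound 4 (0.18 log units; within the scatter). Compound 4 is estimated at 6 mL/min/kg, with a range from 3 mL/min/kg to 12 mL/min/kg.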

Compound 4, clearance: 9 mL/min/kg
For compound 4 the middle estimate is 1.5-fold (0.18 log units) below the measured one; low and high end bracket the measured number.
By their numbers in this assay, from the lowest: compounds 1, 2, 4 and 3 (each within the scatter of the next, the first and the last beyond it).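

In this assay there is a 2.3-fold higher number from compound 1 to compound 4 (0.35 log units; beyond the scatter) for the swap on the sulfonyl sulfur, so two of the three six-membered non-aromatic rings now stand clear of 1-isopropyl-1H-pyrazol-4-yl, and compound 2 is the one that goes against this. The 4-methylpiperazin-1-yl group is not separated from either 1-acylpiperidin-4-yl group, with a 1.5-fold higher number from compound 2 to compound 4 (0.18 log units; within the scatter) and a 1.2-fold lower number from compound 3 to compound 4 (0.09 log units; within the scatter) both printed as within the scatter. Among these three rings, then, the choice of group on the sulfur does not yet resolve into an order in this assay.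

On these data alone, whether a morpholine or a plain phenyl ring on the same sulfur would fall with compound 1 or with the six-membered rings stays open. Nothing at hand gives a reason for any of these steps.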